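Amino pyrimidine series: methyl on the bridging chain carbon

The compounds below may be only part of what the source reports. "The series", "measured", "known", "first", "only" and "open" are said of these compounds alone.

Compound 3 `Cc1c(N)nc(Nc2ccc(C#N)cc2)nc1Cc1c(F)cccc1F` is the reference point. For the measured compounds named here, in an ADME assay on MT4 cells (Homo sapiens) for cytotoxicity, read by MTT assay (on this read-out lower numbers stand for higher toxicity in this test and higher numbers for lower toxicity in this test), compound 3 gives 45900 nM, one of only two plain numbers in the set. Compound 2 `CC(c1cc(N)nc(Nc2ccc(C#N)cc2)n1)c1c(F)cccc1F` in this assay gives 46100 nM; this value and that of compound 3 lie within the scatter of each other, so no order between them can be read. Compound 1 `Cc1c(Cl)nc(Nc2ccc(C#N)cc2)nc1Cc1c(F)cccc1F` gives in this assay only a limit, > 2690 nM. The step from compound 1 to compound 3 is a step that the limit leaves unreadable from compound 1 to compound 3; it is left unreadable by the limit of > 2690 nM in this assay, at which 1 of the 3 values shown sits, and yields no size.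

Compound 4 `Cc1c(N)nc(Nc2ccc(C#N)cc2)nc1C(C)c1c(F)cccc1F` differs from compound 3 by methyl in place of hydrogen on a saturated chain carbon bound to two aromatic carbons. Going by the values given here, no measured step isolates this change. Compound 2 also carries methyl in place of hydrogen on a saturated chain carbon bound to two aromatic carbons, but it differs from compound 3 in a second place as well, and the two values sit within the scatter. Among the compounds with values here, the single measured step concerns a different change and is unreadable. The step expected in this assay, a 1.0-fold lower number from compound 3 to compound 4 (0.01 log units; within the scatter), is therefore taken as one within the scatter, with no direction assigned. Compound 4 is estimated at 45000 nM, with a range from 15000 nM to 120000 nM.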

Compound 4, half-maximal cytotoxic concentration: 40500 nM
Beside the measured number, compound 4's estimate is 1.1-fold (0.05 log units) above it; low and high end bracket the measured number.
By their numbers in this assay, from the lowest: compounds 4, 3 and 2 (each within the scatter of the next).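

In this assay, for the compounds shown here, methyl in place of hydrogen on a saturated chain carbon bound to two aromatic carbons now has a measured step of its own, a 1.1-fold lower number from compound 3 to compound 4 (0.05 log units; within the scatter) where the earlier compounds offered only a pair differing in two places. The series also gains a reading for methyl in place of hydrogen on an aromatic carbon, a 1.1-fold lower number from compound 2 to compound 4 (0.06 log units; within the scatter) with the chain methyl already present, so compound 4, which carries both methyl groups, lies within the scatter of compound 2 and of compound 3 in these single-place comparisons. Nothing measured here offers a cause for either step.

As far as these compounds go, whether a different group on the saturated chain carbon, such as ethyl, a hydroxyl or a longer chain, would give a step beyond the scatter remains open. From the compounds shown here alone, the step for amino in place of chloro on an aromatic carbon cannot be read, so what that position contributes in this assay also remains open.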